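The source may hold more compounds than are shown below. What is called first, only, known or untested is meant among the compounds shown, and "the series" means these compounds.

Compound 1 `COC(=O)c1c(-c2ccc(OC)cc2)oc2ccccc2c1=O`: > 25 ug/mL
Compound 2 `COC(=O)c1c(-c2ccc(Br)cc2)oc2ccccc2c1=O`: > 25 ug/mL
Compound 3 `COC(=O)c1c(-c2ccc([N+](=O)[O-])cc2)oc2ccccc2c1=O`: > 25 ug/mL

These three compounds were tested in a functional assay on SK-MEL cells (Homo sapiens) for cytotoxicity, read by MTT assay, with a stated time of 6 days (on this read-out lower numbers stand for an effect already at smaller amounts and higher numbers for an effect only at larger amounts of compound), and share one core, differing only in a single group on the outer aromatic ring. Compound 3 gives only a limit, > 25 ug/mL, and not a number. The same is true of the whole set, which rests on (the limit of > 25 ug/mL in this assay, at which 3 of the 3 values shown sit).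

The next compound, compound 4 `COC(=O)c1c(-c2ccc(N)cc2)oc2ccccc2c1=O`, differs from compound 3 as follows: amino in place of nitro on an aromatic carbon. The incoming group sits para to a large group. Amino is a group that none of the three measured compounds carries.

Three measured changes at this same place bear on the question: a step that the two limits leave unreadable from compound 1 to compound 2, a step that the two limits leave unreadable from compound 1 to compound 3 and a step that the two limits leave unreadable from compound 2 to compound 3. None of them has a readable size, so they give no direction for this assay and no sign of a step beyond the scatter. On the strength of a step that the two limits leave unreadable from compound 2 to compound 3 and its two companions, no clear change is expected, and the estimated step is a step that the limit leaves unreadable from compound 3 to compound 4. Another report of a limit would be the likeliest result. For compound 4 the estimate is 30 ug/mL, with an expected range from 14 ug/mL to 60 ug/mL.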

Compound 4, concentration for half-maximal effect: > 25 ug/mL
Compound 4 gave a limit, no number; the forecaster's own chance of this, stated with the estimate: 70%; the middle value is on the limit's open side.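

In this assay compound 4 gives only a limit, > 25 ug/mL, and not a number. Among the compounds shown here, no step from compound 1, compound 2 or compound 3 to compound 4 can be read. The compounds shown leave open whether the four groups on the outer aromatic ring differ at all in this read-out, as the whole set rests on one limit: the limit of > 25 ug/mL in this assay, at which 4 of the 4 values shown sit.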